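A few compounds are considered here, and "the series" means these few. Any claim that something is new, unique, unknown or untested is made for them only; others in the source may bear on it.

Measured so far:
Compound 1 `Cc1ccc(C(/C=C/c2ccc(F)cc2)=N\Nc2nncc3ccccc23)cc1` gives 4.5 nM in a functional assay on OVCAR-3 cells (Homo sapiens) for antiproliferative activity, read by sulforhodamine B assay, with a stated time of 72 h; on this read-out higher numbers stand for weaker inhibition and lower numbers for stronger inhibition.
Compound 2 `NC(=S)NNc1nncc2ccccc12` gives 74 nM.
Compound 3 `O=S(=O)(Nc1ccccn1)c1ccc(Nc2nncc3ccccc23)cc1` gives 83 nM.

All three share the same core. Among these three numbers, compound 3 stands highest, which on this read-out means it holds back the growth of the cells least strongly. Its nearest neighbour is compound 2, whose number lies within the usual scatter, so the two cannot be told apart on these measurements alone. Compound 1 lies far lower, well beyond the scatter, and so is clearly the stronger inhibitor of the three when set against compound 3.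

Compound 4 `O=S(=O)(Nc1nccs1)c1ccc(Nc2nncc3ccccc23)cc1` is the next compound to be tested. It differs from compound 3 in a single place: 1,3-thiazol-2-yl in place of pyridin-2-yl on a sulfonamide nitrogen. Among the compounds with values here, no pair of measured compounds shows what such a swap does here, so nothing in the numbers so far speaks for a large move in either direction. The expectation is a small step, most likely one that stays within the scatter, a 1.2-fold lower number from compound 3 to compound 4 (0.07 log units; within the scatter). On that basis compound 4 is estimated at 70 nM, with a range from 25 nM to 250 nM.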

Compound 4, half-maximal inhibitory concentration: 43 nM
For compound 4 the middle estimate is 1.6-fold (0.21 log units) above the measured one; low and high end bracket the measured number.
By their numbers in this assay, from the lowest: compound 1; then compounds 4, 2 and 3 (each within the scatter of the next).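

Within the data shown here, this is the first pair of measured compounds that differ only in the group on the sulfonamide nitrogen: in this assay, 1,3-thiazol-2-yl in place of pyridin-2-yl gives a 1.9-fold lower number from compound 3 to compound 4 (0.29 log units; within the scatter). A five-membered aromatic ring with two hetero atoms can therefore stand at this place instead of a six-membered aromatic ring with one hetero atom, and the two compounds cannot be told apart on these measurements, although the step lies close to the edge of the usual scatter. Nothing available here offers an explanation for this result.

The compounds shown leave open whether an aromatic ring is needed on the sulfonamide nitrogen at all, a question that a compound with a simple methyl group or a longer alkyl chain at this place could begin to answer. From the compounds shown here alone, it also remains open how much the sulfonamide part itself contributes, as neither compound 3 nor compound 4 differs in just one place from compound 1 or compound 2.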